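A few compounds are considered here, and "the series" means these few. Any claim that something is new, unique, unknown or untested is made for them only; others in the source may bear on it.

Compound 1 `COc1ccc(COc2cc(O)c3c(=O)cc(C)oc3c2[C@H]2CCN(C)C[C@H]2O)cc1`: 23%
Compound 2 `Cc1cc(=O)c2c(O)cc(OCc3ccc([N+](=O)[O-])cc3)c([C@H]3CCN(C)C[C@H]3O)c2o1`: 14%

In a functional assay on HL-60 cells (Homo sapiens) for inhibition, read by MTT assay, with a stated time of 48 h, tested at 10 uM (a lower number here means less inhibition of growth, a higher number more inhibition of growth at the concentration tested), compound 2 stands lowest of the two numbers, and its nearest neighbour is compound 1, the step of a number 9 percentage points lower from compound 1 to compound 2 (within the scatter) lying within the scatter. Compound 3 `Cc1cc(=O)c2c(O)cc(OC/C=C/c3ccccc3)c([C@H]3CCN(C)C[C@H]3O)c2o1` differs from compound 2 by 2-phenylethenyl in place of 4-nitrophenyl on a saturated chain carbon bound to an oxygen on an aromatic ring. Within the data shown here, no measured step bears directly on this change; the one step known, a number 9 percentage points lower from compound 1 to compound 2 (within the scatter), changes a different part of the molecule and is within the scatter. The expected step of a number 6 percentage points higher from compound 2 to compound 3 (within the scatter) is therefore not beyond the scatter. Compound 3 is expected to give 20%, with a range from 5% to 40%.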

Compound 3, percent growth inhibition at one concentration: 21%
Beside the measured number, compound 3's estimate is 1 percentage points below it; the measured number falls inside the stated range.
By their numbers in this assay, from the lowest: compounds 2, 3 and 1 (each within the scatter of the next).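

In this assay, the change on a saturated chain carbon bound to an oxygen on an aromatic ring gives a number 7 percentage points higher from compound 2 to compound 3 (within the scatter) with 2-phenylethenyl in place of 4-nitrophenyl, and a number 2 percentage points lower from compound 1 to compound 3 (within the scatter) with 2-phenylethenyl in place of 4-methoxyphenyl. This position therefore now holds three different groups, one of them with no hydrogen-bond acceptors, and none separates from the others in this read-out. No evidence on the reason for this is at hand. As far as these compounds go, all three groups carry an aromatic ring, so it remains open whether an amine, a carboxylic acid or a longer alkyl chain at this position would move the number beyond the scatter.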